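A few compounds are considered here, and "the series" means these few. Any claim that something is new, unique, unknown or untested is made for them only; others in the source may bear on it.

Among the compounds with values here, compound 1 `COc1ccccc1/C=C/C(=O)/C=C/c1ccc(OCc2cn(CCCCOc3cc(=O)oc4ccccc34)nn2)c(OC)c1` is one of three compounds measured in a functional assay on THP-1 cells (Homo sapiens) for inhibition, read by sulforhodamine B assay, with a stated time of 48 h, tested at 50 uM; a higher number here means more inhibition of growth at the concentration tested, a lower number less inhibition of growth. In this assay compound 1 gives 40%, the second highest of the three numbers. Compound 2 `COc1ccccc1/C=C/C(=O)/C=C/c1ccc(OCc2cn(CCCCCOc3cc(=O)oc4ccccc34)nn2)c(OC)c1` gives 37%, a number within the scatter of compound 1, so no order between the two can be claimed. Within the data shown here, compound 3 `COc1cc(/C=C/C(=O)/C=C/c2cccc3ccccc23)ccc1OCc1cn(CCCOc2cc(=O)oc3ccccc23)nn1` gives 71%, a number beyond the scatter above compound 1; no structural step between compound 1 and compound 3 is described here, so only the two values themselves can be compared.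

Compound 4 `COc1ccc(/C=C/C(=O)/C=C/c2ccc(OCc3cn(CCCCOc4cc(=O)oc5ccccc45)nn3)c(OC)c2)cc1OC` has not yet been measured. It differs from compound 1 in one place: 3,4-dimethoxyphenyl in place of 2-methoxyphenyl on a double-bonded chain carbon bound to a double-bonded chain carbon. Among the measured compounds shown here, no measured pair with this same change is available, so the size of the step cannot be read from the data. The change adds a methoxy group to the aryl end of the dienone and leaves the rest of the shared core untouched, so the step from compound 1 to compound 4 is expected to be small, with a number 5 percentage points higher from compound 1 to compound 4 (within the scatter) as the estimated step and its direction uncertain. For compound 4 the expected value in this assay is 45%, estimated to lie between 25% and 65%.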

Compound 4, percent growth inhibition at one concentration: 59%
The estimate for compound 4 lay 14 percentage points below the measured number; measured number inside the range.
By their numbers in this assay, from the lowest: compounds 2 and 1 (each within the scatter of the next); then compound 4; then compound 3.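

In this assay, placing 3,4-dimethoxyphenyl in place of 2-methoxyphenyl on a double-bonded chain carbon bound to a double-bonded chain carbon gives a number 19 percentage points higher from compound 1 to compound 4 (beyond the scatter). Within the data shown here, this is the first step that can be read, and it shows that the group at this place can move growth inhibition by more than the scatter while the rest of the shared core stays the same. No measurement shown here accounts for this step.

This single pair swaps one substitution pattern for another, so it cannot tell whether the step comes from one methoxy group, from both, or from their arrangement on the ring. As far as these compounds go, how an unsubstituted phenyl, a 4-hydroxyphenyl or a 4-dimethylaminophenyl would read at this place also remains open.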